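The source may report more compounds than this note shows. Statements on the series, on what has been measured and on what is new or still open speak of the compounds shown alone.

Among the compounds with values here, compound 3 `COc1cc(-c2cc(=O)c3cc(O)ccc3o2)cc(OC)c1OC` is the one member of this small set to give a number in a functional assay on HT-29 cells (Homo sapiens) for cytotoxicity, read by MTT assay, with a stated time of 6 days; a higher number here means that more compound is needed for the effect, a lower number that less compound is needed: compound 3 gives 7.85 ug/mL. Compound 2 `COc1ccc2oc(-c3ccc(O)cc3)c(C(=O)O)c(=O)c2c1` sits at a limit of the assay, > 25 ug/mL. Compound 1 `COC(=O)c1c(-c2ccc(O)cc2)oc2ccc(OC)cc2c1=O` likewise sits at a limit, > 25 ug/mL. The step that the two limits leave unreadable from compound 2 to compound 1, (methyl in place of hydrogen on an oxygen next to a carbonyl group), therefore cannot be read because of the limit of > 25 ug/mL in this assay, at which 2 of the 3 values shown sit. Within the data shown here, compound 4 `COc1ccc2oc(-c3cc(OC)c(OC)c(OC)c3)cc(=O)c2c1` is not yet measured; it differs from compound 3 by methyl in place of hydrogen on an oxygen on an aromatic ring, the same kind of change as the one between compound 2 and compound 1 but at a different place, on an oxygen on an aromatic ring whose other neighbours are aromatic carbon rather than on an oxygen next to a carbonyl group whose other neighbours are carbonyl carbon. How the core of compound 3 differs from that of compound 2 is not broken down here. With no readable precedent, the expectation rests on compound 3 alone and its 7.85 ug/mL. Compound 4 is estimated at 10 ug/mL, between 3 ug/mL and 30 ug/mL. That estimate means a step of a 1.3-fold higher number from compound 3 to compound 4 (0.11 log units; within the scatter).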

Compound 4, concentration for half-maximal effect: > 25 ug/mL
Compound 4 ended at the assay's limit (the forecaster's own chance of this, stated with the estimate: 25%); middle value at least 2.5-fold (0.39 log units) away from the limit.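

In this assay, the change from hydroxy to methoxy, methyl in place of hydrogen on an oxygen on an aromatic ring, gives an at least 3.1-fold higher number from compound 3 to compound 4 (0.50 log units; beyond the scatter). From the compounds shown here alone, this shows that the change costs activity on the core of compound 3, and compound 4 sits at a limit, so the full size of the step stays unknown. It does not show that the change carries over to another core, as the related step from compound 2 to compound 1 sits at a different place and cannot be read because both of its values are limits: the limit of > 25 ug/mL in this assay, at which 3 of the 4 values shown sit.

The compounds shown leave open how an amine or a longer chain, such as ethoxy, would behave in place of the hydroxy of compound 3. They also leave open whether the same change would have any readable effect on the core of compound 1.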